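A few compounds are considered here, and "the series" means these few. Any claim that something is new, unique, unknown or untested is made for them only; others in the source may bear on it.

In a functional assay on HCT-116 cells (Homo sapiens) for cytotoxicity, read by MTT assay, with a stated time of 72 h (a higher number here means a weaker inhibitor, a lower number a stronger inhibitor), compound 1 `NS(=O)(=O)c1cc(-c2nnc(CN3CCN(c4ccccc4)CC3)o2)c(Cl)cc1SCc1ccccc1` gives 105000 nM, compound 2 `[N-]=[N+]=NCc1nnc(-c2cc(S(N)(=O)=O)c(SCc3ccccc3)cc2Cl)o1` gives 100000 nM and compound 3 `NS(=O)(=O)c1cc(-c2nnc(CNC(=O)c3ccccc3)o2)c(Cl)cc1SCc1ccccc1` gives 42000 nM, the lowest of the three numbers. Two measured steps lead to compound 3: a 2.5-fold lower number from compound 1 to compound 3 (0.40 log units; beyond the scatter) and a 2.4-fold lower number from compound 2 to compound 3 (0.38 log units; beyond the scatter). Compound 4 `NS(=O)(=O)c1cc(-c2nnc(/C=C/c3c(Cl)cccc3Cl)o2)c(Cl)cc1SCc1ccccc1` differs from compound 3 by 2-(2,6-dichlorophenyl)ethenyl in place of benzamidomethyl on an aromatic carbon. Within the data shown here, no measured step swaps that whole group, so the expectation rests on the observation that every change tried at this position has shifted this assay only modestly, as a 2.5-fold lower number from compound 1 to compound 3 (0.40 log units; beyond the scatter) and a 2.4-fold lower number from compound 2 to compound 3 (0.38 log units; beyond the scatter) show. A step of a 1.2-fold higher number from compound 3 to compound 4 (0.08 log units; within the scatter) is therefore expected, small and possibly not beyond the scatter. Compound 4 is estimated at 50000 nM, with a likely range from 15000 nM to 150000 nM.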

Compound 4, half-maximal inhibitory concentration: 32000 nM
Compound 4: middle estimate off by 1.6-fold (0.19 log units), on the high side, and the stated range covers the measured number.
By their numbers in this assay, from the lowest: compounds 4 and 3 (each within the scatter of the next); then compounds 2 and 1 (each within the scatter of the next).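

The hydrogen-bond donor and acceptor of benzamidomethyl are absent from 2-(2,6-dichlorophenyl)ethenyl, yet the swap stays small, with a 1.3-fold lower number from compound 3 to compound 4 (0.12 log units; within the scatter). Set against azidomethyl, the same group gives a 3.1-fold lower number from compound 2 to compound 4 (0.49 log units; beyond the scatter), so a group without an amide can match the best result at this position. Nothing measured here explains these shifts. Still open, from the compounds shown here alone, is whether a carboxylic acid or a primary amine at this position would lower the number further. A plain 2-phenylethenyl group would show whether the two chlorines matter.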